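Working notes on the shared core, from compound 3 to compound 4

The source may report more compounds than this note shows. Statements on the series, on what has been measured and on what is new or still open speak of the compounds shown alone.

Measured compounds in a functional assay on the whole organism with Mus musculus as the target, in the writhing test; a higher number here means that more compound is needed for the effect, a lower number that less compound is needed:
- compound 1, `CC(=O)N1CCC(Sc2c[nH]c3ccc(Br)cc23)CC1`, compound 1 gives 2.9 mg/kg
- compound 2, `CCOC(=O)N1CCC(Sc2c[nH]c3ccc(Br)cc23)CC1`, compound 2 gives 6.3 mg/kg
- compound 3, `CON1CCC(Sc2c[nH]c3ccc(Cl)cc23)CC1`, compound 3 gives 1.4 mg/kg

Compound 3 holds the lowest number of the three in this assay; compound 1 stands nearest to it and compound 2 furthest, and both gaps lie beyond the scatter. Among the compounds with values here, the single measured step, a 2.2-fold higher number from compound 1 to compound 2 (0.34 log units; beyond the scatter), concerns the group on the carbonyl carbon and is modest in size.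

Compound 4 is `CON1CCC(Sc2c[nH]c3ccc(Br)cc23)CC1`. It differs from compound 3 by bromo in place of chloro on an aromatic carbon. Within the data shown here, no measured step touches this change: compounds 1 and 2 both carry bromo, compound 3 carries chloro, and the rest of their structures differ elsewhere, so the pair gives no isolated reading of the swap. The exchange is small in what leaves and enters, and the expectation is therefore a step in this assay that stays within the scatter, with no direction favoured.

On that basis compound 4 is expected to give about 1.6 mg/kg in this assay, within a range of 0.7 mg/kg to 3.5 mg/kg, meaning an estimated step of a 1.1-fold higher number from compound 3 to compound 4 (0.06 log units; within the scatter).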

Compound 4, dose for half-maximal effect: 1.6 mg/kg
Estimate against measurement, compound 4: no gap at the digits printed, within the range that was stated.
By their numbers in this assay, from the lowest: compounds 3, 4 and 1 (each within the scatter of the next, the first and the last beyond it); then compound 2.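

In this assay, the change at this aromatic carbon now has an isolated reading, a 1.1-fold higher number from compound 3 to compound 4 (0.06 log units; within the scatter), so the compounds shown do not separate bromo from chloro here. With bromo held constant, the group on the amine nitrogen in a ring can also be read: methoxy against ethoxycarbonyl gives a 3.9-fold lower number from compound 2 to compound 4 (0.60 log units; beyond the scatter), while methoxy against acetyl gives a 1.8-fold lower number from compound 1 to compound 4 (0.26 log units; within the scatter), so only the first of these two exchanges separates the groups. No data at hand bear on the reason for any of these steps.

As far as these compounds go, the halogen reading rests on a single pair carrying methoxy on the nitrogen, so its behaviour with acetyl or ethoxycarbonyl there remains open. Also open, from the compounds shown here alone, is how fluoro or methyl at the aromatic carbon, or a longer alkoxy chain on the nitrogen, would read in this assay.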